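Cyano for Trifluoromethoxy on a Bad-Binding Core

A few compounds are considered here, and "the series" means these few. Any claim that something is new, unique, unknown or untested is made for them only; others in the source may bear on it.

Compound 1 `CN(C)CC[C@H](CSc1ccccc1)Nc1ccc(S(=O)(=O)NC(=O)c2ccc(N3CCN(Cc4ccccc4-c4ccc(Cl)cc4)CC3)cc2)cc1OC(F)(F)F` was tested in an assay on isolated protein for displacement of a labelled ligand from Bcl2-associated agonist of cell death (Homo sapiens), read by fluorescence polarization; on this read-out higher numbers stand for weaker inhibition and lower numbers for stronger inhibition. In this assay compound 1 gives < 1 nM, which is a limit of the assay rather than a number. Compound 2 `O=C(NS(=O)(=O)c1ccc(NCCSc2ccccc2)c([N+](=O)[O-])c1)c1ccc(N2CCN(Cc3ccccc3-c3ccc(Cl)cc3)CC2)cc1` gives < 1 nM, again a limit of the assay. Compound 3 `CN(C)CC[C@H](CSc1ccccc1)Nc1ccc(S(=O)(=O)NC(=O)c2ccc(N3CCN(C/C4=C(\c5ccc(Cl)cc5)CCCCCC4)CC3)cc2)cc1[N+](=O)[O-]` gives < 1 nM, also a limit of the assay. Compound 1 therefore stands where every measured value stands, because the limit of < 1 nM in this assay, at which 3 of the 3 values shown sit: no one of the three is distinguished from the others by the numbers shown.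

Compound 4 `CN(C)CC[C@H](CSc1ccccc1)Nc1ccc(S(=O)(=O)NC(=O)c2ccc(N3CCN(Cc4ccccc4-c4ccc(Cl)cc4)CC3)cc2)cc1C#N` has not yet been measured. It differs from compound 1 in one place: cyano in place of trifluoromethoxy on an aromatic carbon. For the measured compounds named here, no step between two measured compounds is available to calibrate this change, so the expectation for compound 4 rests on where compound 1 sits and on the three values all lying at the same limit. The step from compound 1 to compound 4 is expected to be a step that the limit leaves unreadable from compound 1 to compound 4, a change within the usual scatter. Compound 4 is therefore estimated at 0.7 nM, with a range from 0.2 nM to 3 nM, and it is expected that this assay most likely reports only a limit again.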

Compound 4, inhibition constant: < 1 nM
Compound 4 was reported as a limit; the forecaster's own chance of this, stated with the estimate: 70%; the middle value is on the limit's open side.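

For the compounds shown here, no step from compound 1 to compound 4 can be read, because both values are limits of the assay: the limit of < 1 nM in this assay, at which 4 of the 4 values shown sit.

The compounds shown leave open whether cyano and trifluoromethoxy differ at all in this assay, and how the four compounds would rank beyond that limit.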